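The compounds below may be only part of what the source reports. "The series", "measured", "known", "first", "only" and "open" are said of these compounds alone.

Measured in a functional assay on HepG2 cells (Homo sapiens) for inhibition, read by MTT assay, with a stated time of 48 h; a higher number here means a weaker inhibitor, a lower number a stronger inhibitor:
Compound 1 `COc1ccc(N(C)c2nc(C)nc3ccccc23)cc1OCCC[Se]C#N`: 1040 nM
Compound 2 `C[Se]c1ccc(N(C)c2nc(C3CC3)nc3ccccc23)cc1`: 32 nM

Compound 1 has the higher of the two numbers, which makes it the weaker inhibitor, and the gap to compound 2 lies beyond the scatter. The two differ in more than one place, so this gap says little about a single change.

Compound 3 `COc1ccc(N(C)c2nc(C)nc3ccccc23)cc1C(=O)OCC[Se]C#N`, not yet measured, keeps the core of compound 1 and alters one group: a group of 8 heavy atoms (4 carbon, 1 nitrogen, 2 oxygen, 1 selenium; no ring) in place of a group of 7 heavy atoms (4 carbon, 1 nitrogen, 1 oxygen, 1 selenium; no ring), on an aromatic carbon. The group sits on an aromatic carbon, ortho to a methoxy group. Within the data shown here, no measured pair shows what such a swap does in this assay. Starting from compound 1 at 1040 nM, a swap this small is expected to cause no shift beyond the scatter, in neither direction. The expected size is a 1.2-fold lower number from compound 1 to compound 3 (0.06 log units; within the scatter). For compound 3 the estimated value is 900 nM, with an expected range of 280 nM to 3000 nM.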

Compound 3, half-maximal inhibitory concentration: 890 nM
Beside the measured number, compound 3's estimate is 1.0-fold (0.00 log units) above it; measured number inside the range.
By their numbers in this assay, from the lowest: compound 2; then compounds 3 and 1 (each within the scatter of the next).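

In this assay, the group of 8 heavy atoms in place of the group of 7 heavy atoms on this aromatic carbon, ortho to a methoxy group, gives a 1.2-fold lower number from compound 1 to compound 3 (0.07 log units; within the scatter) and so no shift that can be told from the scatter. Among these compounds, this is the first single-place comparison in the set, and it shows that this position tolerates this swap, with an added double bond and one more hydrogen-bond acceptor, without a clear gain or loss. Nothing measured here indicates why the two groups give such similar numbers.

As far as these compounds go, whether a much shorter group, an amine or a carboxylic acid on this carbon would behave the same stays open. Compound 2 differs from compound 1 and compound 3 in more than one place, so no single change can be linked to its lower number.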